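Methoxy additions on a bromoacrylamide chalcone series

The source may hold more compounds than are shown below. What is called first, only, known or untested is meant among the compounds shown, and "the series" means these compounds.

Compound 1 `C=C(Br)C(=O)Nc1ccc(C(=O)/C=C/c2ccccc2OC)cc1` gives 580 nM in an ADME assay on CCRF-CEM cells (Homo sapiens) for antiproliferative activity, with a stated time of 48 h; on this read-out lower numbers stand for stronger inhibition and higher numbers for weaker inhibition. Compound 2 `C=C(Br)C(=O)Nc1ccc(C(=O)/C=C/c2cccc(OC)c2OC)cc1` differs by one change, (methoxy in place of hydrogen on an aromatic carbon), which made a 1.2-fold higher number from compound 1 to compound 2 (0.09 log units; within the scatter); compound 2 gives 710 nM. Compound 3 `C=C(Br)C(=O)Nc1ccc(C(=O)/C=C/c2cc(OC)cc(OC)c2)cc1` shares the core, but how its core differs from that of compound 1 is not broken down here; compound 3 gives 2200 nM, the highest of the three numbers. Compound 4 `C=C(Br)C(=O)Nc1ccc(C(=O)/C=C/c2cc(OC)c(OC)c(OC)c2)cc1` is unmeasured and differs from compound 3 by methoxy in place of hydrogen on an aromatic carbon. This is the same kind of change as from compound 1 to compound 2, though the place differs: here the methoxy enters ortho to two methoxy groups and para to a large group, earlier ortho to a methoxy group and meta to a large group. In this assay the expected step is a 1.2-fold lower number from compound 3 to compound 4 (0.09 log units; within the scatter), resting on a 1.2-fold higher number from compound 1 to compound 2 (0.09 log units; within the scatter) having stayed within the scatter. Compound 4 is estimated at 1800 nM, between 700 nM and 4500 nM.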

Compound 4, half-maximal inhibitory concentration: 330 nM
Compound 4: the middle estimate sits 5.5-fold (0.74 log units) above what was measured; measured number below the stated range.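

In this assay the added methoxy gave a 6.7-fold lower number from compound 3 to compound 4 (0.82 log units; beyond the scatter), and this step does not match the earlier one: the same change on two cores in this assay, a 1.2-fold higher number (0.09 log units; within the scatter) from compound 1 to compound 2 and a 6.7-fold lower number (0.82 log units; beyond the scatter) from compound 3 to compound 4, 8.2-fold (0.91 log units) apart, beyond the scatter of two such steps

So in this series, the step seen on the core of compound 1 did not carry over to the core of compound 3. Within the data shown here, with only one pair on each core, and the methoxy entering at a different place in each, this does not show whether the core or the place sets the gap, nor does it give a rule for other cores.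

As far as these compounds go, it remains open whether an ethoxy or a hydroxy group entering at the same place, ortho to two methoxy groups and para to a large group, would match compound 4. Also open, from the compounds shown here alone, is whether the step would hold with chlorine in place of the bromine.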